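The source may hold more compounds than are shown below. What is called first, only, known or untested is meant among the compounds shown, and "the series" means these compounds.

Measured compounds:
compound 1, `CC(C)CCn1cnc2c(Nc3ccc(Cl)cc3)nc(N[C@H]3CC[C@H](N)CC3)nc21`, 1800 nM
compound 2, `CC(C)CCn1cnc2c(Nc3ccccc3)nc(N[C@H]3CC[C@H](N)CC3)nc21`, 3500 nM
compound 3, `CCCCn1cnc2c(Nc3cccc(Cl)c3)nc(N[C@H]3CC[C@H](N)CC3)nc21`, 2000 nM

All three were run in a functional assay on K562 cells (Homo sapiens) for inhibition, read by fluorescence, with a stated time of 72 h; on this read-out lower numbers stand for stronger inhibition of growth and higher numbers for weaker inhibition of growth. Compound 4, `CCCCn1cnc2c(Nc3ccccc3)nc(N[C@H]3CC[C@H](N)CC3)nc21`, is not yet measured there.

The change from compound 1 to compound 2 is hydrogen in place of chloro on an aromatic carbon. It gave a 1.9-fold higher number from compound 1 to compound 2 (0.29 log units; within the scatter). Compound 4 is reached from compound 3 by hydrogen in place of chloro on an aromatic carbon. The two changes are the same kind of change, not the same: in the first the place is para to a large group, in the second it is meta to a large group. The difference between the core of compound 3 and the core of compound 1 is not broken down here; their values in this assay sit within the scatter of each other, as do those of compound 3 and compound 2.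

Among the compounds with values here, for compound 4 the step is expected at a 1.8-fold higher number from compound 3 to compound 4 (0.24 log units; within the scatter), set beside a 1.9-fold higher number from compound 1 to compound 2 (0.29 log units; within the scatter) as the only measured step of this kind, with the shift of place leaving the direction uncertain. Compound 4 is therefore estimated at 3500 nM, expected between 1800 nM and 7000 nM.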

Compound 4, concentration for 50% growth inhibition: 3200 nM
Beside the measured number, compound 4's estimate is 1.1-fold (0.04 log units) above it; the range from low to high includes it.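

In this assay, hydrogen in place of chloro on the core of compound 3 gives a 1.6-fold higher number from compound 3 to compound 4 (0.20 log units; within the scatter), and the change reads alike on the two cores: the same change on two cores in this assay, a 1.9-fold higher number (0.29 log units; within the scatter) from compound 1 to compound 2 and a 1.6-fold higher number (0.20 log units; within the scatter) from compound 3 to compound 4, 1.2-fold (0.08 log units) apart, within the scatter of two such steps

This shows agreement between two small steps, each within the scatter; it does not show that the chloro group has a real effect on either core, and the 3-chlorophenyl group of compound 3 does not carry its chloro in the same place as compound 1. Between the two cores, hydrogen in place of methyl on a saturated chain carbon gives a 1.1-fold lower number from compound 2 to compound 4 (0.04 log units; within the scatter), also within the scatter, so these two pairs support no rule for carrying the change across the series.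

On these data alone, it stays open whether the chloro group behaves alike when it stands in the same place on both cores. Also open, as far as these compounds go, is whether other groups on the aromatic ring, such as methoxy, trifluoromethyl or an amine, or a longer chain on the core, would give a step beyond the scatter.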